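Working notes: from compound 2 to compound 3

This account rests on a few compounds, and the source may have more. Where it says the series, first, only, none or still open, it means among the compounds named here.

Measured in a functional assay on SW480 cells (Homo sapiens) for antiproliferative activity, read by MTT assay, with a stated time of 48 h; a higher number here means a weaker inhibitor, a lower number a stronger inhibitor:
- compound 1 `CC(C)=CCC[C@]1(C)/C=C/[C@@H](OC(=O)C=C(C)C)[C@](C)(O)/C=C/C(=O)/C(CN(C(C)C)C(C)C)=C\C1`: 750 nM
- compound 2 `CC(C)=CCC[C@]1(C)/C=C/[C@@H](OC(=O)C=C(C)C)[C@](C)(O)/C=C/C(=O)/C(Cn2cc(CO)nn2)=C\C1`: 2870 nM

Of the two measured compounds, compound 2 has the higher number in this assay. Compound 3 `CC(C)=CCC[C@]1(C)/C=C/[C@@H](OC(=O)C=C(C)C)[C@](C)(O)/C=C/C(=O)/C(C(=O)N2CCCC2)=C\C1` differs from it as follows: (pyrrolidin-1-yl)carbonyl in place of (4-(hydroxymethyl)-1H-1,2,3-triazol-1-yl)methyl on a double-bonded ring carbon. In words, (pyrrolidin-1-yl)carbonyl stands in place of (4-(hydroxymethyl)-1H-1,2,3-triazol-1-yl)methyl on a double-bonded ring carbon. Among the compounds with values here, only one measured step bears on this, a modest one that introduced the triazolyl group: a 3.8-fold higher number from compound 1 to compound 2 (0.58 log units; beyond the scatter). Within the data shown here, no measured compound carries the (pyrrolidin-1-yl)carbonyl group, so this guide is weak. Losing the triazolyl group is expected to recover part of that step, though the direction remains uncertain. The expected change is modest, towards a lower number: a 2.2-fold lower number from compound 2 to compound 3 (0.34 log units; beyond the scatter). For compound 3 the estimated value is 1300 nM, with an expected range of 400 nM to 4000 nM.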

Compound 3, half-maximal inhibitory concentration: 15100 nM
Estimate against measurement, compound 3: 12-fold (1.07 log units) below; measured number above the stated range.
By their numbers in this assay, from the lowest: compound 1; then compound 2; then compound 3.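

In this assay, (pyrrolidin-1-yl)carbonyl on this double-bonded ring carbon gives a 5.3-fold higher number from compound 2 to compound 3 (0.72 log units; beyond the scatter) and, against the (diisopropylamino)methyl group, a 20-fold higher number from compound 1 to compound 3 (1.30 log units; beyond the scatter) at the same place. Removing the (4-(hydroxymethyl)-1H-1,2,3-triazol-1-yl)methyl group therefore does not by itself bring the number back towards that of compound 1, and the position separates all three groups, with the order running from (diisopropylamino)methyl through the triazolyl group to (pyrrolidin-1-yl)carbonyl. No measurement here accounts for this order.

Still open, as far as these compounds go, is whether the step follows the carbonyl or the pyrrolidine ring, as the two enter together and a (pyrrolidin-1-yl)methyl group would separate them. The compounds shown also leave open how a carboxylic acid or a primary amine at this carbon would stand in the series.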